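Bromo step on a level pair of compounds

The compounds below may be only part of what the source reports. "The series", "measured", "known", "first", "only" and "open" are said of these compounds alone.

In a functional assay on MCF7 cells (Homo sapiens) for cytotoxicity, read by MTT assay, with a stated time of 24 h (a higher number here means a weaker inhibitor, a lower number a stronger inhibitor), compound 1 (`O=C1CC(c2ccccc2)Nc2ccccc21`) gives 4000 nM as its half-maximal inhibitory concentration. Compound 2 (`O=C1CC(c2ccc(O)cc2O)Nc2ccccc21`) gives 4000 nM in the same read-out, so compound 1 stands level with it, within the scatter. Within the data shown here, these two values are all that is in hand, and no measured step between compounds differing in one place is available to calibrate a change.

Compound 3 (`O=C1CC(c2ccc(Br)cc2)Nc2ccccc21`) departs from compound 1 with bromo in place of hydrogen on an aromatic carbon, para to a large group (bromo in place of hydrogen on an aromatic carbon). Among the measured compounds shown here, the data hold no direct precedent for this change. With compound 1 at 4000 nM and compound 2 at 4000 nM showing no separation, no step beyond the scatter is expected in this assay, with only a slight lean toward a lower number. The estimated change is a 1.3-fold lower number from compound 1 to compound 3 (0.12 log units; within the scatter) and is expected to remain within the scatter. Compound 3 is estimated at 3000 nM within an expected range of 1200 nM to 8000 nM in this read-out.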

Compound 3, half-maximal inhibitory concentration: 4000 nM
Compound 3: the middle estimate sits 1.3-fold (0.12 log units) below what was measured; measured number inside the range.
By their numbers in this assay, from the lowest: compounds 1, 2 and 3 (each within the scatter of the next).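

In this assay, among these compounds, bromo in place of hydrogen on an aromatic carbon, para to a large group, supplies the only single-place step in hand for the series, with no change at the digits printed from compound 1 to compound 3 (within the scatter) as its reading. This position on the six-membered aromatic ring of carbon only therefore takes a single bromine atom with no shift beyond the scatter, a finding that rests on this one group in this one read-out. Nothing in hand bears on why the number stays where it is.

As far as these compounds go, whether an amine or a carboxylic acid at this same position would also stay within the scatter of compound 1 remains open, as does the outcome for a methoxy group or a longer chain there. Also open, from the compounds shown here alone, is how other places on the core of compound 1 respond to a single change, so this reading holds only for bromo at this position and does not extend to the rest of the series.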